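Ester Variation on the Shared Core: Cytotoxicity Working Notes

The source may report more compounds than this note shows. Statements on the series, on what has been measured and on what is new or still open speak of the compounds shown alone.

In an ADME assay on L6 cells (Rattus norvegicus) for cytotoxicity, with a stated time of 72 h (a lower number here means a stronger inhibitor, a higher number a weaker inhibitor), compound 3 `CN(C)C12CC(OC(=O)/C=C/c3ccccc3)C(C(c3ccccc3)C1)C(c1ccccc1)C2` gives 3820 nM, the lowest of the three numbers recorded. Compound 2 `CN(C)C12CC(OC(=O)CN3CCCCC3)C(C(c3ccccc3)C1)C(c1ccccc1)C2` gives 29300 nM in this assay, and compound 1 `CCN(CC)CC(=O)OC1CC2(N3CCCC3)CC(c3ccccc3)C1C(c1ccccc1)C2` gives 49000 nM. Among the measured compounds shown here, the only measured step, a 7.7-fold lower number from compound 2 to compound 3 (0.88 log units; beyond the scatter), runs opposite to the change that leads to compound 4 `CCN(CC)CC(=O)OC1CC2(N(C)C)CC(c3ccccc3)C1C(c1ccccc1)C2`: (diethylamino)methyl in place of 2-phenylethenyl on a carbonyl carbon. Compound 2, which carries (piperidin-1-yl)methyl on the carbonyl carbon, and compound 1, which carries (diethylamino)methyl there, both stand well above compound 3 in this assay. A rise of roughly the size of that measured step is therefore expected. Compound 4 is estimated at 32000 nM, within 12000 nM to 90000 nM, an expected step of an 8.4-fold higher number from compound 3 to compound 4 (0.92 log units; beyond the scatter).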

Compound 4, half-maximal inhibitory concentration: 30100 nM
Compound 4: middle estimate off by 1.1-fold (0.03 log units), on the high side; the range from low to high includes it.
By their numbers in this assay, from the lowest: compound 3; then compounds 2, 4 and 1 (each within the scatter of the next).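

In this assay, a 7.9-fold higher number from compound 3 to compound 4 (0.90 log units; beyond the scatter) ties the low number of compound 3 to 2-phenylethenyl on the carbonyl carbon, as a second amine-bearing group, (diethylamino)methyl, also gives a much higher number. Changing the amine matters little by comparison: diethylamino in place of piperidin-1-yl gives a 1.0-fold higher number from compound 2 to compound 4 (0.01 log units; within the scatter), and dimethylamino in place of pyrrolidin-1-yl gives a 1.6-fold lower number from compound 1 to compound 4 (0.21 log units; within the scatter). No measurement at hand accounts for these differences. From the compounds shown here alone, whether 2-phenylethyl, which lacks the double bond, or a plain phenyl on the carbonyl carbon would keep the lower number remains open.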